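The compounds below may be only part of what the source reports. "The series", "measured", "known", "first", "only" and "open" are said of these compounds alone.

Values in a functional assay on DU-145 cells (Homo sapiens) for cytotoxicity, read by trypan blue exclusion, with a stated time of 96 h; a lower number here means a stronger inhibitor, a higher number a weaker inhibitor
compound 1 `COc1ccc(NS(=O)(=O)/C=C/c2c(OC)cc(OC)cc2OC)cc1` gives 200 nM
compound 2 `COC(=O)CNc1cc(NS(=O)(=O)/C=C/c2c(OC)cc(OC)cc2OC)ccc1OC` gives 350 nM

Among the measured compounds shown here, compound 2 lies within the scatter of the only other measured value, so the series has no clear order yet. Compound 3 `COC(=O)C(C)(C)Nc1cc(NS(=O)(=O)/C=C/c2c(OC)cc(OC)cc2OC)ccc1OC` carries 1-(methoxycarbonyl)-1-methylethyl in place of (methoxycarbonyl)methyl on a nitrogen on an aromatic ring, as counted here: 1-(methoxycarbonyl)-1-methylethyl in place of (methoxycarbonyl)methyl on a nitrogen on an aromatic ring. For the measured compounds named here, the sole guide is a 1.8-fold higher number from compound 1 to compound 2 (0.24 log units; within the scatter), which comes from ((methoxycarbonyl)methyl)amino in place of hydrogen on an aromatic carbon. That step introduces the side chain and does not test a change within it, so it offers only weak support and no direction. No shift beyond the scatter is expected in this assay for this change. The expected result is a 1.1-fold higher number from compound 2 to compound 3 (0.06 log units; within the scatter), with wide margins. For compound 3 the estimate is 400 nM, with an expected range from 150 nM to 1200 nM.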

Compound 3, half-maximal inhibitory concentration: 200 nM
Compound 3: the middle estimate sits 2.0-fold (0.30 log units) above what was measured, within the range that was stated.
By their numbers in this assay, from the lowest: compounds 1, 3 and 2 (each within the scatter of the next).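

Among the compounds shown here, on the nitrogen on the aromatic ring, 1-(methoxycarbonyl)-1-methylethyl in place of (methoxycarbonyl)methyl gives a 1.8-fold lower number from compound 2 to compound 3 (0.24 log units; within the scatter) in this assay and so, for the first time, a change within the side chain has been read, and the two side chains do not separate. Set against hydrogen on the aromatic carbon, (1-(methoxycarbonyl)-1-methylethyl)amino gives no change at the digits printed from compound 1 to compound 3 (within the scatter) and so this position now holds two different ester-bearing amino groups with no shift beyond the scatter. Nothing available explains why these numbers stay so close.

All three compounds leave open whether the position stays this flat with a free carboxylic acid in place of the methyl ester, or with a simple amine or a longer chain. On these data alone, whether any side chain here can move the number beyond the scatter also remains open.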